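Benzylamine sulfonamide series: methoxy for chloro on compound 1

A few compounds are considered here, and "the series" means these few. Any claim that something is new, unique, unknown or untested is made for them only; others in the source may bear on it.

Measured compounds:
compound 1 `O=S(=O)(NCCCNCc1ccc(Cl)cc1)c1cc(C(F)(F)F)cc(C(F)(F)F)c1`: 1600 nM
compound 2 `O=S(=O)(NCCCNCc1ccc(Br)cc1)c1cc(C(F)(F)F)cc(C(F)(F)F)c1`: 1500 nM
compound 3 `O=S(=O)(NCCCNCc1ccc(Cl)c(Cl)c1)c1cc(C(F)(F)F)cc(C(F)(F)F)c1`: 1400 nM

In a functional assay on BXPC-3 cells (Homo sapiens) for inhibition, read by MTT assay, with a stated time of 72 h (a lower number here means a stronger inhibitor of growth, a higher number a weaker inhibitor of growth), compound 1 gives 1600 nM and carries the highest of the three numbers, yet its steps to the other two are small: a 1.1-fold lower number from compound 1 to compound 2 (0.03 log units; within the scatter) and a 1.1-fold lower number from compound 1 to compound 3 (0.06 log units; within the scatter) both stay within the scatter, so the three compounds cannot be told apart on these data.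

Compound 4 `COc1ccc(CNCCCNS(=O)(=O)c2cc(C(F)(F)F)cc(C(F)(F)F)c2)cc1` is the next member to be tested. It differs from compound 1 in one place: methoxy in place of chloro on an aromatic carbon. Among the compounds with values here, no measured pair exchanges chloro for methoxy. The two steps that touch this part of the molecule, a 1.1-fold lower number from compound 1 to compound 2 (0.03 log units; within the scatter) and a 1.1-fold lower number from compound 1 to compound 3 (0.06 log units; within the scatter), exchange one halogen for another or add a halogen, and neither moves the number beyond the scatter, so the benzylamine ring substituent has so far been silent in this assay. On that basis the step of a 1.1-fold higher number from compound 1 to compound 4 (0.03 log units; within the scatter) is expected to be small, with no direction beyond the scatter. Compound 4 is estimated at 1700 nM, expected between 800 nM and 3600 nM.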

Compound 4, concentration for 50% growth inhibition: 1300 nM
Compound 4: middle estimate off by 1.3-fold (0.12 log units), on the high side; the measured number falls inside the stated range.
By their numbers in this assay, from the lowest: compounds 4, 3, 2 and 1 (each within the scatter of the next).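

Within the data shown here, the 4-methoxyphenyl group is the first substituent at this position that is not a halogen, yet in this assay every step to it stays within the scatter: a 1.2-fold lower number from compound 1 to compound 4 (0.09 log units; within the scatter), a 1.2-fold lower number from compound 2 to compound 4 (0.06 log units; within the scatter) and a 1.1-fold lower number from compound 3 to compound 4 (0.03 log units; within the scatter). The silence of this ring substituent therefore extends beyond the halogens to a group that carries a hydrogen-bond acceptor, with no exception among compound 1, compound 2, compound 3 and compound 4. No evidence on hand bears on this flat result.

As far as these compounds go, whether any substituent at this position can move the number remains open, for example a carboxylic acid or an amine on the same ring. From the compounds shown here alone, the shared core is also constant throughout, so the effect of a longer chain linking the sulfonamide to the benzylamine nitrogen remains unknown.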